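Swapping One Aryl Group on a Very Weak Compound

This account rests on a few compounds, and the source may have more. Where it says the series, first, only, none or still open, it means among the compounds named here.

In a functional assay on NCI/ADR-RES cells (Homo sapiens) for inhibition (on this read-out lower numbers stand for stronger inhibition of growth and higher numbers for weaker inhibition of growth), compound 1 `O=S(=O)(/C=C/c1ccc(C(F)(F)F)cc1F)Cc1ccc(Nc2ncnc3ccccc23)cc1` gives 100000 nM, a high number that stands for weak inhibition of growth.

Compound 2 `O=S(=O)(/C=C/c1ccc(Cl)cc1Cl)Cc1ccc(Nc2ncnc3cc(Cl)ccc23)cc1` stands at > 100000 nM, which is a limit of this assay and not a number.

On these data alone, compound 2 therefore has no exact reading, and how far it lies past that limit is unknown.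

Compound 3 `O=S(=O)(/C=C/c1ccc(C(F)(F)F)cc1F)Cc1ccc(Nc2ncnc3cc(Cl)ccc23)cc1` keeps everything in compound 2 except one group: 2-fluoro-4-(trifluoromethyl)phenyl in place of 2,4-dichlorophenyl on a double-bonded chain carbon bound to a double-bonded chain carbon. In words, 2-fluoro-4-(trifluoromethyl)phenyl takes the place of 2,4-dichlorophenyl on a double-bonded chain carbon bound to a double-bonded chain carbon.

Within the data shown here, no measured pair of compounds shows what this swap does on its own. Among the measured compounds shown here, the only guide is compound 1, which carries the same entering group and still gives 100000 nM, so little gain in inhibition is expected.

The expected change is a number no higher from compound 2 to compound 3 (the limit leaves the size open), which means no step beyond the usual scatter in this assay.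

For compound 3 the estimate is 100000 nM, with an expected range from 40000 nM to 200000 nM.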

Compound 3, concentration for 50% growth inhibition: > 100000 nM
Compound 3: only a limit was reported (the forecaster's own chance of this, stated with the estimate: 55%); the middle value lies on the limit itself.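

With compound 3, the 2-fluoro-4-(trifluoromethyl)phenyl group and the chloro group on the shared core stand together in one molecule. In this assay compound 3 gives > 100000 nM, which is a limit and not a number, so this swap of the aryl group on a double-bonded chain carbon bound to a double-bonded chain carbon does not bring the compound to a readable value. Chloro in place of hydrogen on an aromatic carbon goes with a number no lower from compound 1 to compound 3 (the limit leaves the size open). Neither the aryl swap nor chloro in place of hydrogen on an aromatic carbon can be sized as a step, because each comparison rests on a limit: the limit of > 100000 nM in this assay, at which 2 of the 3 values shown sit.

On these data alone, how far compound 2 and compound 3 lie past that limit stays open, and so does whether they differ from each other at all or from compound 1. Also open, as far as these compounds go, is whether an amine or a carboxylic acid in place of the aryl group on that chain carbon would give a readable number.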